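Shortening the chain substituent: compound 3 to compound 4

A few compounds are considered here, and "the series" means these few. Any claim that something is new, unique, unknown or untested is made for them only; others in the source may bear on it.

Three analogues sharing one core have been run in a functional assay on the whole organism (strain Swiss) with Mus musculus as the target, in the maximal electroshock model, with a stated time of 0.25 h, at a dose of 300 mg/kg by the intraperitoneal route; a lower number here means a weaker effect, a higher number a stronger effect of the compound at the dose given. Compound 1 `CC(C(=O)N1CCN(c2ccc(Cl)cc2)CC1)N1C(=O)CCC1=O` gives 100%. Compound 2 `CC(C(=O)N1CCN(c2ccccc2F)CC1)N1C(=O)CCC1=O` gives 100%. Among the measured compounds shown here, the single step between measured compounds differing in one place, no change at the digits printed from compound 1 to compound 2 (within the scatter), swaps the aryl group on the amine nitrogen in the ring without moving the read-out. Compound 3 `CCC(C(=O)N1CCN(c2cccc(C)c2)CC1)N1C(=O)CCC1=O` gives 100%, level with compounds 1 and 2 at the digits shown; its nearest neighbour is compound 1 and its furthest is compound 2, and neither gap exceeds the scatter.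

Compound 4 `Cc1cccc(N2CCN(C(=O)C(C)N3C(=O)CCC3=O)CC2)c1` is the unmeasured member. Relative to compound 3 the difference is hydrogen in place of methyl on a saturated chain carbon, two bonds along the chain from an amide-type nitrogen in a ring and a carbonyl carbon; cut one bond further out, the same change reads ethyl to methyl. Compounds 1 and 2 already carry the methyl on that chain carbon, and their read-outs lie within the scatter of compound 3. For the measured compounds named here, no measured step addresses this chain change directly, and the only step available is itself within the scatter. The expected step is therefore no change at the digits printed from compound 3 to compound 4 (within the scatter), nothing beyond the scatter. Compound 4 is estimated at 100% with a range from 80% to 100%.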

Compound 4, a percentage reported as activity, at one dose (the size of the read-out at that dose, not a potency): 100%
Beside the measured number, compound 4's estimate shows no gap at the digits printed, within the range that was stated.
By their numbers in this assay, from the lowest: compounds 1, 2, 3 and 4 (each within the scatter of the next).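

In this assay, among the compounds shown here, the change of hydrogen in place of methyl on a saturated chain carbon, two bonds along the chain from an amide-type nitrogen in a ring and a carbonyl carbon, gives no change at the digits printed from compound 3 to compound 4 (within the scatter); with the 3-methylphenyl group held constant, this is the first direct reading of ethyl to methyl at this position, and it leaves the read-out unmoved. With methyl on that chain carbon in all three compounds, 3-methylphenyl in place of 2-fluorophenyl gives no change at the digits printed from compound 2 to compound 4 (within the scatter), and 3-methylphenyl in place of 4-chlorophenyl gives no change at the digits printed from compound 1 to compound 4 (within the scatter), so the aryl swap that earlier stood as a single step now holds across three aryl groups on the same chain. No supporting data bear on why the read-out stays level at this position.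

Because this assay reports one dose, these level read-outs separate neither the chain groups nor the aryl groups by potency. As far as these compounds go, whether a longer chain such as propyl, or an amine or a carboxylic acid on that chain carbon, would hold the read-out at this level remains open.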